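Swapping an Ether Ring for a Hydroxycyclohexyl Group

This account rests on a few compounds, and the source may have more. Where it says the series, first, only, none or still open, it means among the compounds named here.

Compound 2, `COc1ccc(Cn2c(-c3ccccc3)c(-c3ccccc3)c3c(=N)n(CC4CCOCC4)cnc32)cc1`, has been measured in an ADME assay for permeability, using PAMPA, with a stated time of 30 min, at pH 7.4 (a lower number here means that the compound crosses the layer more slowly, a higher number that the compound crosses the layer faster), where compound 2 gives 1270 10^-6 cm/s. Among the measured compounds shown here, that is the only plain number in this small set. Compound 1, `COc1ccc(Cn2c(-c3ccccc3)c(-c3ccccc3)c3c(=N)n(CCO)cnc32)cc1`, gives in this assay a reading of > 1000 10^-6 cm/s, which is a limit of the assay rather than a number. Compound 3, `COc1ccc(Cn2c(-c3ccccc3)c(-c3ccccc3)c3c(=N)n([C@H]4CC[C@H](O)CC4)cnc32)cc1`, has not yet been measured. The change from compound 2 to compound 3 is 4-hydroxycyclohexyl in place of (oxan-4-yl)methyl on an aromatic nitrogen; the two have the same atoms, joined differently. For the measured compounds named here, the only measured comparison, a step that the limit leaves unreadable from compound 1 to compound 2, cannot be read in size because of the limit of > 1000 10^-6 cm/s in this assay, at which 1 of the 2 values shown sits, so no measured step gives a usable size for the present change. What remains is that both measured compounds sit at the high end of the scale, which suggests that compound 3 is expected to stay high as well, perhaps somewhat lower. The step from compound 2 to compound 3 is estimated at a 1.4-fold lower number from compound 2 to compound 3 (0.15 log units; within the scatter). For compound 3 in this assay the estimate is 900 10^-6 cm/s, with a range from 400 10^-6 cm/s to 1500 10^-6 cm/s.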

Compound 3, apparent permeability: > 1000 10^-6 cm/s
Compound 3: only a limit was reported; the forecaster's own chance of this, stated with the estimate: 40%; middle value at least 1.1-fold (0.04 log units) from the limit.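

In this assay compound 3 gives > 1000 10^-6 cm/s as a limit and not a number. Neither the step from compound 1 to compound 3 nor the step from compound 2 to compound 3 can be read in size, for this reason: the limit of > 1000 10^-6 cm/s in this assay, at which 2 of the 3 values shown sit. The compounds shown leave open whether 2-hydroxyethyl, (oxan-4-yl)methyl and 4-hydroxycyclohexyl on the aromatic nitrogen differ at all in this read-out.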